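The compounds below may be only part of what the source reports. "The series", "measured", "known", "first", "only" and "open" are said of these compounds alone.

Series notes. In an assay on isolated protein for activation of Insulin-degrading enzyme (Homo sapiens), read by fluorescence, with stated times of 10 min and 20 min (a higher number here means that more compound is needed for the effect, a lower number that less compound is needed), compound 1 `O=C(CCCc1cn(C(=O)c2cccs2)c2ccccc12)NCCCn1ccnc1` gives 21400 nM. Compound 2 `O=C(CCCc1cn(S(=O)(=O)c2ccccc2)c2ccccc12)NCCCn1ccnc1` gives 13200 nM, a change of a 1.6-fold lower number from compound 1 to compound 2 (0.21 log units; within the scatter). Among the compounds with values here, compound 3 `O=C(CCCc1cn(S(=O)(=O)c2ccccc2F)c2ccccc12)NCCCn1ccnc1` gives 7940 nM, the lowest of the three numbers so far; against the others it shows a 2.7-fold lower number from compound 1 to compound 3 (0.43 log units; beyond the scatter) and a 1.7-fold lower number from compound 2 to compound 3 (0.22 log units; within the scatter). Compound 4 `O=C(CCCc1cn(S(=O)(=O)c2ccc(F)cc2)c2ccccc12)NCCCn1ccnc1` differs from compound 3 by 4-fluorophenyl in place of 2-fluorophenyl on a sulfonyl sulfur. Within the data shown here, no measured step moves the fluorine to another position on the ring; the only step involving fluorine, a 1.7-fold lower number from compound 2 to compound 3 (0.22 log units; within the scatter), lies within the scatter, so the present change is expected to give no step beyond the scatter in this assay, in either direction. The expected step is a 1.0-fold higher number from compound 3 to compound 4 (0.00 log units; within the scatter). Compound 4 is therefore estimated at 8000 nM, with a range from 4000 nM to 16000 nM.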

Compound 4, half-maximal effective concentration: 6760 nM
Compound 4: the middle estimate sits 1.2-fold (0.07 log units) above what was measured, and the stated range covers the measured number.
By their numbers in this assay, from the lowest: compounds 4, 3, 2 and 1 (each within the scatter of the next, the first and the last beyond it).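

Moving the fluorine, with 4-fluorophenyl in place of 2-fluorophenyl on a sulfonyl sulfur, is not resolved in this assay (a 1.2-fold lower number from compound 3 to compound 4 (0.07 log units; within the scatter)). Fluoro in place of hydrogen on an aromatic carbon also stays within the scatter in this second example (a 2.0-fold lower number from compound 2 to compound 4 (0.29 log units; within the scatter)), while (4-fluorophenyl)sulfonyl in place of (thiophen-2-yl)carbonyl goes beyond it (a 3.2-fold lower number from compound 1 to compound 4 (0.50 log units; beyond the scatter)). Nothing available explains these steps. Open, going by these compounds, is whether a methoxy group, an amine or a carboxylic acid on this phenyl ring would give a step beyond the scatter.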